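The source may report more compounds than this note shows. Statements on the series, on what has been measured and on what is new or still open speak of the compounds shown alone.

The measured compounds:
compound 1, `O=C(NO)c1ccc(/C=C/c2ccnc(-c3cccc(O)c3)c2)cc1`, 19 nM
compound 2, `O=C(NO)c1ccc(/C=C/c2ccnc(-c3cccc(CO)c3)c2)cc1`, 34 nM
compound 3, `COc1ccc(-c2cc(/C=C/c3ccc(C(=O)NO)cc3)ccn2)cc1`, 110 nM

All three share one core, a hydroxamic acid linked through a double bond to a ring holding one nitrogen, and differ only in the group carried on that ring. In an assay on isolated protein for inhibition of protein deacetylase HDAC6 (Homo sapiens), read by fluorescence, with a stated time of 15 min (a lower number here means a stronger inhibitor, a higher number a weaker inhibitor), compound 3 gives the highest of the three numbers, so it is the weakest inhibitor among them. Its nearest neighbour is compound 2, and the step of a 3.2-fold higher number from compound 2 to compound 3 (0.51 log units; beyond the scatter) lies beyond the scatter; the step of a 5.8-fold higher number from compound 1 to compound 3 (0.76 log units; beyond the scatter) is larger still. By contrast, the step of a 1.8-fold higher number from compound 1 to compound 2 (0.25 log units; within the scatter) stays within the scatter.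

Compound 4, `O=C(NO)c1ccc(/C=C/c2ccnc(Br)c2)cc1`, has not yet been measured. It differs from compound 3 by bromo in place of 4-methoxyphenyl on an aromatic carbon; the new group sits next to the ring nitrogen and meta to a large group. Among the measured compounds shown here, none of the measured steps removes the whole aromatic ring; all of them exchange one substituted phenyl for another, and even those exchanges moved the number as far as a 5.8-fold higher number from compound 1 to compound 3 (0.76 log units; beyond the scatter). Cutting the group down to a single atom is a greater change than any of those, so a further rise in the number, beyond the scatter, is the expected outcome, though its size is uncertain because the data hold no comparable step. The estimate for compound 4 in this assay is 300 nM, with a range from 60 nM to 1500 nM, which would mean an expected step of a 2.7-fold higher number from compound 3 to compound 4 (0.44 log units; beyond the scatter).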

Compound 4, half-maximal inhibitory concentration: 320 nM
Estimate against measurement, compound 4: 1.1-fold (0.03 log units) below; the range from low to high includes it.
By their numbers in this assay, from the lowest: compounds 1 and 2 (each within the scatter of the next); then compound 3; then compound 4.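

In this assay, the position next to the ring nitrogen tolerates losing the whole phenyl ring, but the cost depends on which ring is lost. Bromo in place of 4-methoxyphenyl gives a 2.9-fold higher number from compound 3 to compound 4 (0.46 log units; beyond the scatter), while bromo in place of 3-(hydroxymethyl)phenyl gives a 9.4-fold higher number from compound 2 to compound 4 (0.97 log units; beyond the scatter) and bromo in place of 3-hydroxyphenyl gives a 17-fold higher number from compound 1 to compound 4 (1.23 log units; beyond the scatter), so all three substituted phenyl groups give lower numbers than bromo, and the advantage varies with the phenyl group. No measurement here explains why the number moves with these groups.

It remains open how much of this advantage comes from the phenyl ring itself, since unsubstituted phenyl does not appear among these compounds. Nor do they show how a 3-aminophenyl or 3-carboxyphenyl group would compare with the 3-hydroxyphenyl of compound 1.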